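Swapping Methyl for Methoxy on the Benzyl Arm

The source may report more compounds than this note shows. Statements on the series, on what has been measured and on what is new or still open speak of the compounds shown alone.

Of the compounds shown here, three sharing one core have been measured in an assay on cell membranes from kidney for displacement of a labelled ligand from Translocator protein (Rattus norvegicus); a lower number here means a stronger inhibitor, a higher number a weaker inhibitor. For the measured compounds named here, compound 1 `CCN(Cc1ccccc1)C(=O)c1nc(-c2ccccc2Cl)c2ccccc2n1` gives 0.235 nM, and compound 2 `CCN(Cc1ccccc1)C(=O)c1nc(-c2ccc(Cl)cc2)c2ccccc2n1` gives 0.762 nM; the one single-point step between measured compounds, a 3.2-fold higher number from compound 1 to compound 2 (0.51 log units; beyond the scatter), concerns the aromatic ring attached directly to the core. Compound 3 `CCN(Cc1ccc(C)cc1)C(=O)c1nc(-c2ccccc2)c2ccccc2n1` gives 2.57 nM, the highest of the three numbers and thus the weakest inhibitor among them, with gaps to compound 2 and compound 1 that both lie beyond the scatter.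

Compound 4 `CCN(Cc1ccc(OC)cc1)C(=O)c1nc(-c2ccccc2)c2ccccc2n1` has not been measured. It differs from compound 3 in one place: methoxy in place of methyl on an aromatic carbon. Going by the values given here, the single recorded step sits on the other aromatic ring, so no measured step bears on a change made on the benzyl arm. With nothing directly comparable to lean on, no movement beyond the scatter is expected for compound 4, and the expected step of a 1.0-fold lower number from compound 3 to compound 4 (0.01 log units; within the scatter) is small. Compound 4 is therefore estimated at 2.5 nM, in a range from 0.9 nM to 7 nM.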

Compound 4, inhibition constant: 2.77 nM
Estimate against measurement, compound 4: 1.1-fold (0.04 log units) below; measured number inside the range.
By their numbers in this assay, from the lowest: compound 1; then compound 2; then compounds 3 and 4 (each within the scatter of the next).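

On the benzyl arm, methoxy in place of methyl gives a 1.1-fold higher number from compound 3 to compound 4 (0.03 log units; within the scatter) in this assay, so compound 4 and compound 3 cannot be told apart in this test, even though the swap adds one oxygen and one hydrogen-bond acceptor. This is the first step shown on the benzyl arm, as the earlier step concerned the aromatic ring attached directly to the core, and it shows that at this place, para to a large group, these two groups read alike. No separate measurement bears on this result.

Going by these compounds, whether an amine or a carboxylic acid at this place would read the same remains open, as does the outcome for a longer chain such as butoxy. Also open, on these data alone, is how either group on the benzyl arm would combine with the 2-chlorophenyl group of compound 1.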